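Trimethoxyphenyl hydrazone in the diaryl ether urea series

A few compounds are considered here, and "the series" means these few. Any claim that something is new, unique, unknown or untested is made for them only; others in the source may bear on it.

Compound 3 `COc1ccc(/C=N/NC(=O)Nc2ccc(Oc3ccnc(-c4nncn4CCN(C)C)c3)c(F)c2)cc1O` gives 620 nM in a functional assay on NCI-H460 cells (Homo sapiens) for cytotoxicity, read by MTT assay, with a stated time of 72 h; on this read-out higher numbers stand for weaker inhibition and lower numbers for stronger inhibition. Among the three measured compounds it stands second highest: compound 1 `CN(C)CCn1cnnc1-c1cc(Oc2ccc(NC(=O)N/N=C/c3cccc(Cl)c3Cl)cc2F)ccn1` gives 72 nM, while compound 2 `CN(C)CCn1cnnc1-c1cc(Oc2ccc(NC(=O)N/N=C/c3ccc(O)c(O)c3)cc2F)ccn1` gives 1930 nM, so compound 3 sits between them, nearer to compound 2.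

Compound 4 `COc1ccc(/C=N/NC(=O)Nc2ccc(Oc3ccnc(-c4nncn4CCN(C)C)c3)c(F)c2)c(OC)c1OC` is the next step from compound 3: 2,3,4-trimethoxyphenyl in place of 3-hydroxy-4-methoxyphenyl on a carbon with a double bond to nitrogen.

Among the measured compounds shown here, two measured steps bear on this. The change from a dichlorophenyl to an oxygenated phenyl cost potency, a 27-fold higher number from compound 1 to compound 2 (1.43 log units; beyond the scatter) and an 8.6-fold higher number from compound 1 to compound 3 (0.94 log units; beyond the scatter). Within the oxygenated phenyls, replacing a hydroxyl hydrogen with a methyl helped, a 3.1-fold lower number from compound 2 to compound 3 (0.49 log units; beyond the scatter). For the measured compounds named here, compound 4 removes the last hydroxyl and carries three methoxy groups, so a further lowering of the number in this assay is expected, of a size comparable to the methylation step already seen, though the extra methoxy groups have no precedent in the measured set. The estimated step is a 2.1-fold lower number from compound 3 to compound 4 (0.32 log units; beyond the scatter). Compound 4 is therefore expected at about 300 nM, with a plausible range from 100 nM to 1000 nM.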

Compound 4, half-maximal inhibitory concentration: 1790 nM
Compound 4: the middle estimate sits 6.0-fold (0.78 log units) below what was measured, outside the stated range (above it).
By their numbers in this assay, from the lowest: compound 1; then compound 3; then compounds 4 and 2 (each within the scatter of the next).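

In this assay the methylation gain of a 3.1-fold lower number from compound 2 to compound 3 (0.49 log units; beyond the scatter) does not continue on this carbon with a double bond to nitrogen, and 2,3,4-trimethoxyphenyl instead reverses it with a 2.9-fold higher number from compound 3 to compound 4 (0.46 log units; beyond the scatter) in this series. With a 1.1-fold lower number from compound 2 to compound 4 (0.03 log units; within the scatter) the 2,3,4-trimethoxyphenyl and the 3,4-dihydroxyphenyl cannot be told apart, which leaves compound 3 clear of both among the oxygenated phenyls, while the 2,3-dichlorophenyl remains well ahead with a 25-fold higher number from compound 1 to compound 4 (1.40 log units; beyond the scatter) on this read-out. Nothing measured here accounts for the reversal.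

The compounds shown do not separate the loss of the hydroxyl from the gain of further methoxy groups. From the compounds shown here alone, how an amine or a single chlorine on this phenyl would read in this assay also stays open, and the same holds for a single methoxy group.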